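The source may hold more compounds than are shown below. What is called first, only, known or untested is meant among the compounds shown, and "the series" means these compounds.

Measured compounds:
Compound 1, `COc1cccc(S(=O)(=O)c2ccccc2)c1Cc1c2c(n(CC(=O)O)c1C)CCNC2=O`: in a functional assay on CHO.K1 cells for antagonist activity at prostaglandin D2 receptor 2 (Homo sapiens), read by GTPgammaS binding, with a stated time of 1 h (on this read-out higher numbers stand for weaker inhibition and lower numbers for stronger inhibition), compound 1 gives 4500 nM.
Compound 2, `Cc1c(Cc2ccccc2S(=O)(=O)c2cccc(Cl)c2)c2c(n1CC(=O)O)CCNC2=O`: in this assay compound 2 gives 4 nM.

Of the two numbers seen so far, compound 2 holds the lower one, and compound 1 stands far above it; the gap between them lies well beyond the usual scatter of the assay. For the measured compounds named here, no pair of measured compounds differs in a single place, so the effect of any one change has not yet been observed directly.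

Compound 3, `Cc1c(Cc2ccccc2S(=O)(=O)C2CCCCC2)c2c(n1CC(=O)O)CCNC2=O`, has not been measured. It differs from compound 2 in one place: cyclohexyl in place of 3-chlorophenyl on a sulfonyl sulfur. Going by the values given here, nothing among the measured compounds shows what swapping an aromatic ring for a non-aromatic one at this point does on the shared core, so the expectation rests on the value of compound 2 alone and carries a wide range. The step of a 3.8-fold higher number from compound 2 to compound 3 (0.57 log units; beyond the scatter) is expected to be a modest weakening, smaller than the gap that separates the two measured compounds. The estimate for compound 3 in this assay is 15 nM, with a range from 3 nM to 100 nM.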

Compound 3, half-maximal inhibitory concentration: 28 nM
For compound 3 the middle estimate is 1.9-fold (0.27 log units) below the measured one, within the range that was stated.
By their numbers in this assay, from the lowest: compound 2; then compound 3; then compound 1.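

Read in this assay, the move from a 3-chlorophenyl to a cyclohexyl group on the sulfonyl sulfur gives the first direct comparison on the shared core (a 7.0-fold higher number from compound 2 to compound 3 (0.85 log units; beyond the scatter)), a modest loss of inhibition that lies beyond the scatter. With the non-aromatic ring in place, compound 3 still gives 28 nM, so on this core neither an aromatic ring nor a chlorine atom at this point is required for inhibition at that level, although the pair with compound 2 favours the 3-chlorophenyl group. Nothing given here explains the size of this step.

For the compounds shown here, because the ring and the chlorine change together, the single step cannot show how much of the loss belongs to each; a plain phenyl or a 3-chlorocyclohexyl group on the same core would separate the two. As far as these compounds go, how much ring the sulfonyl sulfur needs also stays open, and a cyclopentyl ring, an isopropyl group or a piperidine ring joined through its nitrogen would each test a different size or atom at this place.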